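Dimethylthiophene sulfonylurea: predicting inhibition from a methyl shift

The source may hold more compounds than are shown below. What is called first, only, known or untested is meant among the compounds shown, and "the series" means these compounds.

Three sulfonylureas share a core; compound 1 `CSc1ccc(S(=O)(=O)NC(=O)Nc2ccc(Cl)cc2)s1`, compound 2 `CCc1ccc(S(=O)(=O)NC(=O)Nc2ccc(Cl)cc2)o1` and compound 3 `Cc1ccsc1S(=O)(=O)NC(=O)Nc1ccc(Cl)cc1` differ only in the ring on the sulfonyl sulfur. In a functional assay on the whole organism (6C3HED cells, Mus musculus) for inhibition, at a dose of 300 mg/kg by the oral route (a higher number here means more inhibition at the dose given (going by the name of the read-out), a lower number less inhibition), compound 1 gives 62%, compound 2 gives 80% and compound 3 gives 62%. Compound 3 is level with compound 1 at the lowest of the three numbers, with no change at the digits printed from compound 1 to compound 3 (within the scatter), while a number 18 percentage points lower from compound 2 to compound 3 (beyond the scatter). Compound 4 `Cc1cc(S(=O)(=O)NC(=O)Nc2ccc(Cl)cc2)sc1C` carries the change (4,5-dimethylthiophen-2-yl in place of 3-methylthiophen-2-yl on a sulfonyl sulfur). The step that bears most on it is no change at the digits printed from compound 1 to compound 3 (within the scatter), a swap of substituents on the same thiophene ring that left the inhibition unchanged; the change from compound 3 to compound 4 is of that kind. A step of a number 3 percentage points higher from compound 3 to compound 4 (within the scatter) is therefore expected, none beyond the scatter. Compound 4 is estimated at 65%, within 50% to 80%.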

Compound 4, a percentage reported as inhibition, in the whole organism at one dose (the size of the read-out at that dose, not a potency): 73%
For compound 4 the middle estimate is 8 percentage points below the measured one; the measured number falls inside the stated range.
By their numbers in this assay, from the lowest: compounds 1 and 3 (each within the scatter of the next); then compounds 4 and 2 (each within the scatter of the next).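

On the sulfonyl sulfur, 4,5-dimethylthiophen-2-yl is the first thiophene shown to separate from another in this assay: there is a number 11 percentage points higher from compound 3 to compound 4 (beyond the scatter) and a number 11 percentage points higher from compound 1 to compound 4 (beyond the scatter), so a change of substituents on this ring does not always leave the read-out unmoved. With a number 7 percentage points lower from compound 2 to compound 4 (within the scatter), this ring cannot be told apart from 5-ethylfuran-2-yl. No measurement at hand explains these differences. The compounds shown leave open whether the rise needs both methyl groups of 4,5-dimethylthiophen-2-yl, and how a thiophene carrying an amine, a carboxylic acid or a longer chain such as propyl would compare at this sulfonyl sulfur.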